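Enantiomer of compound 2 and its expected binding

This account rests on a few compounds, and the source may have more. Where it says the series, first, only, none or still open, it means among the compounds named here.

Among the compounds with values here, compound 2 `N=C(N)NCCCCNC(=O)/C=C/c1ccc2c(c1)[C@@H](C(=O)NCCCCNC(=N)N)[C@H](c1ccc(O)cc1)O2` gives the lowest of the two numbers so far in an assay on isolated protein (Salivary gland) for displacement of a labelled ligand from Alpha-1A adrenergic receptor (Rattus norvegicus) (a lower number here means a stronger inhibitor, a higher number a weaker inhibitor), with 290000 nM. Its nearest neighbour is compound 1 `COC(=O)[C@@H]1c2cc(/C=C/C(=O)NCCCCNC(=N)N)ccc2O[C@H]1c1ccc(O)cc1`, which gives 560000 nM; the step of a 1.9-fold lower number from compound 1 to compound 2 (0.29 log units; within the scatter) changes a group on a carbonyl carbon. Compound 3 `N=C(N)NCCCCNC(=O)/C=C/c1ccc2c(c1)[C@H](C(=O)NCCCCNC(=N)N)[C@@H](c1ccc(O)cc1)O2` differs from compound 2 in this way: the two compounds have the same atoms and bonds; at least one stereo element is drawn with a configuration in one of them and without one in the other: 2 of 5 stereo elements differ; a stereocentre at a saturated ring carbon is drawn R in compound 2 and S in compound 3; a stereocentre at a saturated ring carbon is drawn R in compound 2 and S in compound 3. Within the data shown here, no measured step concerns a change of stereochemistry, so the only guidance is that the single known step lay within the scatter. Compound 3 is therefore expected to stay near compound 2, with a step of no change at the digits printed from compound 2 to compound 3 (within the scatter), and is estimated at 290000 nM with a range from 90000 nM to 1000000 nM.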

Compound 3, half-maximal inhibitory concentration: 310000 nM
Beside the measured number, compound 3's estimate is 1.1-fold (0.03 log units) below it; low and high end bracket the measured number.
By their numbers in this assay, from the lowest: compounds 2, 3 and 1 (each within the scatter of the next).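

Inverting both stereocentres at saturated ring carbons leaves the number in this assay within the scatter (a 1.1-fold higher number from compound 2 to compound 3 (0.03 log units; within the scatter)), so this position shows no measurable preference for either drawn configuration. The earlier step concerned only a group on a carbonyl carbon and said nothing about configuration. This reading carries one qualification: the fact that one of compounds 2 and 3 is drawn with a defined configuration and the other without, at the place where they differ.

On these data alone, whether a primary amine in place of the terminal guanidine groups, or a longer chain, would move any number beyond the scatter remains open.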